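The source may report more compounds than this note shows. Statements on the series, on what has been measured and on what is new or still open speak of the compounds shown alone.

Of the compounds shown here, three of a shared core have been measured in an ADME assay on Caco-2 cells (Homo sapiens) for permeability, read by LC-MS, in the apical to basolateral direction, with a stated time of 60 min, at pH 6.5; on this read-out lower numbers stand for lower permeability and higher numbers for higher permeability. Compound 1 `CC(C)(C)C[C@@H](O)C(=O)N1N=CC[C@H]1C(=O)NCc1cc(Cl)ccc1-n1cnnn1` gives 24 10^-6 cm/s. Compound 2 `CC(C)(C)[C@@H](O)C(=O)N1N=CC[C@H]1C(=O)NCc1cc(Cl)ccc1-n1cnnn1` gives 15 10^-6 cm/s. Compound 3 `CC(C)(C)[C@@H](O)C(=O)N1NCC[C@H]1C(=O)NCc1cc(Cl)ccc1-n1cnnn1` gives 7.2 10^-6 cm/s, the lowest of the three numbers; its nearest neighbour is compound 2, and the largest gap separates it from compound 1. The difference between the cores of compound 2 and compound 3 is not broken down here.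

Compound 1 and compound 2 differ in one place: neopentyl in place of tert-butyl on a saturated chain carbon bound to a carbonyl carbon and an oxygen on a saturated carbon. That change brought a 1.6-fold higher number from compound 2 to compound 1 (0.20 log units; within the scatter).

Compound 4 `CC(C)(C)C[C@@H](O)C(=O)N1NCC[C@H]1C(=O)NCc1cc(Cl)ccc1-n1cnnn1` has not yet been measured. It is related to compound 3 by neopentyl in place of tert-butyl on a saturated chain carbon bound to a carbonyl carbon and an oxygen on a saturated carbon, the same change that relates compound 2 to compound 1, and the place is described in the same words for both pairs. Among the compounds shown the change occurs twice in all, once measured and once not.

Among the measured compounds shown here, the only measured example of the change rests on a single pair, compound 2 to compound 1, and this is the sole basis for what follows. Compound 4 is expected to give 11.5 10^-6 cm/s, which means an estimated step of a 1.6-fold higher number from compound 3 to compound 4 (0.20 log units; within the scatter), a step of about the same size as the earlier one, because the earlier instance gave a 1.6-fold higher number from compound 2 to compound 1 (0.20 log units; within the scatter).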

Compound 4, apparent permeability: 15 10^-6 cm/s
Beside the measured number, compound 4's estimate is 1.3-fold (0.12 log units) below it; the range from low to high includes it.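

In this assay, among the compounds shown here, neopentyl in place of tert-butyl on a saturated chain carbon bound to a carbonyl carbon and an oxygen on a saturated carbon gave a 2.1-fold higher number from compound 3 to compound 4 (0.32 log units; beyond the scatter), and this step can be set against the one on the other core: the same change on two cores in this assay, a 1.6-fold higher number (0.20 log units; within the scatter) from compound 2 to compound 1 and a 2.1-fold higher number (0.32 log units; beyond the scatter) from compound 3 to compound 4, 1.3-fold (0.11 log units) apart, within the scatter of two such steps The change therefore carried over from the core of compound 2 to the core of compound 3 with the same direction and with no size difference that stands out from the scatter, although only the step on the core of compound 3 is by itself beyond the scatter. This does not show that the change will behave alike on other cores, since it rests on two pairs in a single assay, and those two cores differ from each other in only one place; nor does it explain why the number rises.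

The compounds shown leave open whether a longer chain, or a cyclohexyl group, at this same place would extend the step or reverse it. They also leave open whether the step would survive on a core carrying a further change, such as an amine or a carboxylic acid.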